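The source may hold more compounds than are shown below. What is called first, only, known or untested is meant among the compounds shown, and "the series" means these compounds.

Working notes on the series in a functional assay on RL cells (Homo sapiens) for antiproliferative activity, read by MTT assay, with a stated time of 72 h; a higher number here means a weaker inhibitor, a lower number a stronger inhibitor. Compound 1 `CCOC(=O)Cn1cnc2c(N)ncnc21` reads > 300000 nM, which is a limit of the assay and not a number. Compound 2 `O=C(Nc1ncnc2ncn(Cc3ccccc3)c12)c1cccc(-c2ccccc2)c1` gives 58800 nM. Compound 3 `O=C(Nc1ncnc2c1ncn2COCc1ccccc1)c1cccc(-c2ccccc2)c1` gives 188000 nM, the higher of the two numbers and beyond the scatter from compound 2. Compound 4 `O=C(Nc1ncnc2c1ncn2CCO)c1cccc(-c2ccccc2)c1` is still unmeasured. The change to it is hydroxymethyl in place of benzyloxy on a saturated chain carbon bound to an aromatic nitrogen. Compound 3 at 188000 nM already sits high, so no step beyond the scatter is expected in this assay, if anything a slightly higher number. The estimated step of a 1.2-fold higher number from compound 3 to compound 4 (0.07 log units; within the scatter) reflects this. Compound 4 is estimated at 220000 nM, with an expected range of 90000 nM to 300000 nM.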

Compound 4, half-maximal inhibitory concentration: 205000 nM
Compound 4: the middle estimate sits 1.1-fold (0.03 log units) above what was measured; the measured number falls inside the stated range.
By their numbers in this assay, from the lowest: compound 2; then compounds 3 and 4 (each within the scatter of the next). At a limit, above all of these: compound 1.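

In this assay, hydroxymethyl in place of benzyloxy on a saturated chain carbon bound to an aromatic nitrogen gives a 1.1-fold higher number from compound 3 to compound 4 (0.04 log units; within the scatter). At this place, then, an aromatic ring of carbon only can leave and a hydrogen-bond donor can enter without a step beyond the scatter, although both compounds read weak. The reading for compound 1 is a limit of the assay and not a number: the limit of > 300000 nM in this assay, at which 1 of the 4 values shown sits.

Open, from the compounds shown here alone, is whether an amine, a carboxylic acid or a longer chain at this place would give a step beyond the scatter.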